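A Second Chloro Group on the Fused Core

The source may report more compounds than this note shows. Statements on the series, on what has been measured and on what is new or still open speak of the compounds shown alone.

Compound 1 `ClCc1ccccc1Cn1cnc2c(Cl)nc(Cl)nc21`: 1510 nM
Compound 2 `ClCc1ccccc1Cn1cnc2c(Cl)ncnc21`: 2180 nM
Compound 3 `ClCc1cccc(Cn2cnc3c(Cl)ncnc32)c1`: 2450 nM

In a functional assay on NCI/ADR-RES cells (Homo sapiens) for cytotoxicity, read by sulforhodamine B assay, with a stated time of 48 h (a lower number here means a stronger inhibitor of growth, a higher number a weaker inhibitor of growth), the three measured compounds give numbers that all lie within the usual scatter of one another. Compound 1 differs from compound 2 by chloro in place of hydrogen on an aromatic carbon, and that change gave a 1.4-fold lower number from compound 2 to compound 1 (0.16 log units; within the scatter). Compound 3 and compound 2 have the same atoms joined differently; the difference between the two cores is not broken down here. Compound 4 `ClCc1cccc(Cn2cnc3c(Cl)nc(Cl)nc32)c1` has not yet been measured. It differs from compound 3 by chloro in place of hydrogen on an aromatic carbon, the same change as that from compound 2 to compound 1, with the surroundings of the place described in identical words. A step of similar size is therefore expected, a 1.4-fold lower number from compound 3 to compound 4 (0.15 log units; within the scatter), because the earlier step was a 1.4-fold lower number from compound 2 to compound 1 (0.16 log units; within the scatter). Compound 4 is estimated to give 1750 nM, with a likely range from 900 nM to 3500 nM.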

Compound 4, concentration for 50% growth inhibition: 2390 nM
Compound 4: the middle estimate sits 1.4-fold (0.14 log units) below what was measured; the measured number falls inside the stated range.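

In this assay, chloro in place of hydrogen on an aromatic carbon gave a 1.0-fold lower number from compound 3 to compound 4 (0.01 log units; within the scatter). Set beside the earlier step, the change behaves alike on the two cores: the same change on two cores in this assay, a 1.4-fold lower number (0.16 log units; within the scatter) from compound 2 to compound 1 and a 1.0-fold lower number (0.01 log units; within the scatter) from compound 3 to compound 4, 1.4-fold (0.15 log units) apart, within the scatter of two such steps. For the compounds shown here, neither step lies beyond the scatter, so the pair shows only that two small steps agree, not that the chloro group changes growth inhibition on either core.

The compounds shown leave open whether an amine, a methoxy group or a longer chain on that same aromatic carbon would give a step beyond the scatter. Also open, going by these compounds, is how the numbers in this assay would respond if a carboxylic acid stood in place of the chloromethyl group.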